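Lengthening an Ester Chain on a Weak Growth Inhibitor

The source may hold more compounds than are shown below. What is called first, only, known or untested is meant among the compounds shown, and "the series" means these compounds.

For the measured compounds named here, compound 1 `COC(=O)c1cc(-n2cc(-c3cc(O)ccc3O)nn2)ccc1O` is one of two compounds measured in a functional assay on CCRF-CEM cells (Homo sapiens) for inhibition, read by MTT assay, with a stated time of 2 days; a higher number here means a weaker inhibitor of growth, a lower number a stronger inhibitor of growth. Here compound 1 gives 13900 nM, the highest of the two numbers. The other measured compound, compound 2 `COc1ccccc1-c1cn(-c2ccc(O)c(C(=O)Nc3cccc(C(F)(F)F)c3)c2)nn1`, gives 10500 nM in this assay; the two values lie within the ordinary scatter of repeated measurements, so no order between them can be claimed.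

Compound 3 `O=C(OCCCc1ccccc1)c1cc(-n2cc(-c3cc(O)ccc3O)nn2)ccc1O` has not yet been measured. It differs from compound 1 in one place: phenethyl in place of hydrogen on a saturated chain carbon bound to an oxygen next to a carbonyl group. Going by the values given here, no pair of measured compounds shows the effect of such a change, so nothing here tells how the length of this ester chain matters. With only the value of compound 1 as an anchor, the step is expected to be modest, a 2.0-fold lower number from compound 1 to compound 3 (0.30 log units; within the scatter), leaning toward a somewhat lower number but with wide uncertainty. Compound 3 is therefore expected to give about 7000 nM in this assay, with a range from 2000 nM to 25000 nM.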

Compound 3, concentration for 50% growth inhibition: 930 nM
Compound 3: middle estimate off by 7.5-fold (0.88 log units), on the high side; the whole stated range lies above it.
By their numbers in this assay, from the lowest: compound 3; then compounds 2 and 1 (each within the scatter of the next).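

In this assay, replacing the methoxy of the ester with 3-phenylpropoxy gives a 15-fold lower number from compound 1 to compound 3 (1.17 log units; beyond the scatter), so this position accepts a much larger group and growth inhibition responds strongly to the change. For the compounds shown here, the two earlier values could not be placed in any order and offered no step to read, which makes this the first clear sign that a change at one place on this core can shift the result beyond the scatter. No measurement shown here says what lies behind the step.

With a single replacement for methyl, the effect of the added chain length cannot be separated from that of the aromatic ring it carries. A benzyl ester, a plain hexyl ester without the ring, or a longer 5-phenylpentyl chain would show which of the two matters and whether the trend continues.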